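One Substituent Swap on the Shared Core

A few compounds are considered here, and "the series" means these few. Any claim that something is new, unique, unknown or untested is made for them only; others in the source may bear on it.

Compound 1, `CC(=O)OC/C1=C/C[C@](C)(CCC=C(C)C)/C=C/[C@@H](OC(=O)C=C(C)C)[C@](C)(O)/C=C/C1=O`, was tested in a functional assay on MCF7 cells (Homo sapiens) for antiproliferative activity, read by MTT assay, with a stated time of 48 h (a lower number here means a stronger inhibitor, a higher number a weaker inhibitor), and gives 4510 nM. Two related compounds were measured alongside it in this assay. Compound 2, `CC(C)=CCC[C@]1(C)/C=C/[C@@H](OC(=O)C=C(C)C)[C@](C)(O)/C=C/C(=O)/C(C[Si](c2ccccc2)(c2ccccc2)C(C)(C)C)=C\C1`, gives 15800 nM, and compound 3, `CC(C)=CCC[C@](C)(/C=C/[C@@H](OC(=O)C=C(C)C)[C@](C)(O)/C=C/C(=O)/C=C/N(C)C)CC=O`, gives 12200 nM. Among these three numbers compound 1 stands lowest: the number for compound 3 is higher than that of compound 1 by more than the usual scatter, and the number for compound 2 is higher still, also beyond the scatter. Compound 1 is therefore the strongest inhibitor of the three.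

Compound 4, `CC(C)=CCC[C@]1(C)/C=C/[C@@H](OC(=O)C=C(C)C)[C@](C)(O)/C=C/C(=O)/C(C(=O)N(C(C)C)C(C)C)=C\C1`, has not yet been measured. It differs from compound 1 in one place: diisopropylcarbamoyl in place of acetoxymethyl on a double-bonded ring carbon. Within the data shown here, no measured pair differs in just this way, so the size of the step has to be estimated from what is known. The other two measured compounds both give higher numbers than compound 1, and compound 4 is expected to follow the same tendency and to be a weaker inhibitor, with a step of a 2.0-fold higher number from compound 1 to compound 4 (0.30 log units; within the scatter) going upward beyond the scatter. On that basis compound 4 is estimated to give 9000 nM in this assay, within a range from 3500 nM to 25000 nM.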

Compound 4, half-maximal inhibitory concentration: 17200 nM
The estimate for compound 4 lay 1.9-fold (0.28 log units) below the measured number; the measured number falls inside the stated range.
By their numbers in this assay, from the lowest: compound 1; then compounds 3, 2 and 4 (each within the scatter of the next).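

Among these compounds, replacing acetoxymethyl with diisopropylcarbamoyl on a double-bonded ring carbon of the shared core gives a 3.8-fold higher number from compound 1 to compound 4 (0.58 log units; beyond the scatter) in this assay and this is the first direct reading of a single change at this position: what sits here matters to the antiproliferative number, and the exchange moves it toward weaker inhibition. The step is modest rather than large, so this position tolerates the bulkier-by-count group, nine heavy atoms against five, with inhibition weakened but still measurable. The change swaps several things at once, an ester oxygen for an amide nitrogen, one more carbon-rich branched group, and one hydrogen-bond acceptor fewer, and no measurement here ties the step to any one of them or explains it.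

Still open, as far as these compounds go, is whether a small amide such as dimethylcarbamoyl, a free hydroxymethyl or a carboxylic acid at this ring carbon would read closer to compound 1 or to compound 4. A single step in one direction also leaves open whether any group here could give a lower number than acetoxymethyl does, for example a longer ester such as butanoyloxymethyl.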